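This account rests on a few compounds, and the source may have more. Where it says the series, first, only, none or still open, it means among the compounds named here.

Of the compounds shown here, two from this series have so far been measured in a functional assay on MIA PaCa-2 cells (Homo sapiens) for antiproliferative activity, read by MTT assay, with a stated time of 3 days; a higher number here means a weaker inhibitor, a lower number a stronger inhibitor. Compound 1, `CCCCCCCCC#Cc1cn(C/C=C/CN2C(=O)c3ccccc3C2=O)c(=O)[nH]c1=O`, carries a different substituent on the shared core. In this assay compound 1 reaches only the limit of the assay, > 100000 nM, and not a number. Compound 2, `CCCCCc1ccc(C#Cc2cn(C/C=C\CN3C(=O)c4ccccc4C3=O)c(=O)[nH]c2=O)cc1`, has the same core with a different group attached and its linker drawn Z. In this assay compound 2 likewise gives only a limit, > 100000 nM. Where compound 2 stands is therefore set by the limit of > 100000 nM in this assay, at which 2 of the 2 values shown sit, so the numbers do not separate compound 2 from compound 1 at all.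

Compound 3, `CCCCCc1ccc(C#Cc2cn(C/C=C/CN3C(=O)c4ccccc4C3=O)c(=O)[nH]c2=O)cc1`, is the next compound to be measured. The change from compound 2 to compound 3 is the two compounds have the same atoms and bonds and differ only in configuration as drawn: 1 of 1 stereo elements differ; a double bond is drawn Z in compound 2 and E in compound 3. Among the measured compounds shown here, no step between measured compounds exists here, so the direction of this change cannot be read from data. The step that the estimate below implies, a step that the limit leaves unreadable from compound 2 to compound 3, is expected to be none beyond the scatter, since compound 2 already sits at the limit. Compound 3 is estimated at 150000 nM in this assay, within 50000 nM to 500000 nM, and most probably will again be reported only as a limit.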

Compound 3, half-maximal inhibitory concentration: 26000 nM
For compound 3 the middle estimate is 5.8-fold (0.76 log units) above the measured one; the measured number lies below the stated range.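

In this assay, compound 3 gives the series its first real number, and it shows that the drawn geometry of the linker double bond is enough to move the read-out, with an at least 3.8-fold lower number from compound 2 to compound 3 (0.58 log units; beyond the scatter). At this same position on the triple-bonded carbon, with the E double bond kept, the 4-pentylphenyl group also separates from octyl, with an at least 3.8-fold lower number from compound 1 to compound 3 (0.58 log units; beyond the scatter). The first of these steps can be placed on the double bond alone, as nothing else in the two structures changes: the fact that compounds 2 and 3 differ only in the configuration as drawn

As far as these compounds go, how large the two steps truly are stays open, since each is measured from a compound without a number: the limit of > 100000 nM in this assay, at which 2 of the 3 values shown sit. Also open is whether the E linker would give a number with other groups on the triple-bonded carbon, such as a longer chain, an amine or a carboxylic acid in place of the 4-pentylphenyl group, and whether the Z and E forms would then differ in the same direction.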